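The source may hold more compounds than are shown below. What is called first, only, known or untested is meant among the compounds shown, and "the series" means these compounds.

In an ADME assay on the whole organism (plasma) for pharmacokinetics, with Rattus norvegicus as the target, at a dose of 5 mg/kg by the oral route (a lower number here means less compound in the circulation, a higher number more compound in the circulation at the dose given), compound 1 `CC[C@H](C)[C@@H]1C(=O)N[C@H](C2Cc3ccccc3C2)C(=O)N1[C@@H](C(=O)N1CCOCC1)c1cnc(C)cc1C` gives 1110 ng.h/mL and compound 2 `Cc1ccc([C@H](C(=O)N(C)C)N2C(=O)[C@@H](C3Cc4ccccc4C3)NC(=O)[C@H]2CC(C)C)cn1` gives 2680 ng.h/mL while compound 3 `CC[C@H](C)[C@@H]1C(=O)N[C@H](C2Cc3ccccc3C2)C(=O)N1[C@@H](C(=O)N(C)C)c1ccc(C)nc1C` gives 4730 ng.h/mL at the same dose. Compound 3 therefore stands beyond the scatter of compound 1 but within the scatter of compound 2, so those last two cannot be ranked.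

Compound 4 `CC[C@H](C)[C@@H]1C(=O)N[C@H](C2Cc3ccccc3C2)C(=O)N1[C@@H](C(=O)N(C)C)c1cnc(C)cc1C` has not yet been measured and differs from compound 3 in one place. The change 4,6-dimethylpyridin-3-yl in place of 2,6-dimethylpyridin-3-yl on a saturated chain carbon bound to an amide-type nitrogen in a ring and a carbonyl carbon puts 4,6-dimethylpyridin-3-yl in place of 2,6-dimethylpyridin-3-yl on a saturated chain carbon bound to an amide-type nitrogen in a ring and a carbonyl carbon.

For the measured compounds named here, no measured pair here differs in one place only, so this swap has no direct precedent. Going by the values given here, the only guide is loose: compound 1 carries the same 4,6-dimethylpyridin-3-yl group and gives 1110 ng.h/mL in this assay but differs from compound 4 elsewhere as well. A modest drop is therefore expected, one that may not leave the scatter. The expected step of a 1.6-fold lower number from compound 3 to compound 4 (0.20 log units; within the scatter) is only an estimate and is small. Compound 4 is estimated at 3000 ng.h/mL with an expected range from 1200 ng.h/mL to 7000 ng.h/mL in this study.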

Compound 4, area under the concentration-time curve: 2690 ng.h/mL
Compound 4: middle estimate off by 1.1-fold (0.05 log units), on the high side, and the stated range covers the measured number.
By their numbers in this assay, from the lowest: compound 1; then compounds 2, 4 and 3 (each within the scatter of the next).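

In this assay, 4,6-dimethylpyridin-3-yl in place of 2,6-dimethylpyridin-3-yl on the saturated chain carbon gives a 1.8-fold lower number from compound 3 to compound 4 (0.25 log units; within the scatter), which lies within the scatter, so the two dimethylpyridinyl groups cannot be told apart at this position in this read-out. For the compounds shown here, compound 4 also provides the first comparison at the carbonyl carbon that changes in one place only: with 4,6-dimethylpyridin-3-yl held fixed, dimethylamino in place of morpholin-4-yl gives a 2.4-fold higher number from compound 1 to compound 4 (0.38 log units; beyond the scatter), a modest step beyond the scatter, and the only one of the two new steps that can be read as a real difference. Nothing measured here bears on either result, so neither step can be given a cause.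

The compounds shown leave open whether dimethylamino in place of morpholin-4-yl would give a similar step alongside 2,6-dimethylpyridin-3-yl, and how a pyrrolidin-1-yl group on that carbonyl carbon would compare. They also leave open how a plain phenyl ring on the saturated chain carbon would compare with either dimethylpyridin-3-yl group.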